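The source may hold more compounds than are shown below. What is called first, only, known or untested is meant among the compounds shown, and "the series" means these compounds.

Compound 1 `CC1CCN(c2nc(C(F)(F)F)ccc2CNC(=O)C(c2ccccc2)c2ccc(NS(C)(=O)=O)c(F)c2)CC1` gives 1.3 nM in an assay on CHO cells for antagonist activity at transient receptor potential cation channel subfamily V member 1 (Homo sapiens), read by FLIPR; on this read-out lower numbers stand for stronger inhibition and higher numbers for weaker inhibition.
Compound 2 `CC1CCN(c2nc(C(F)(F)F)ccc2CNC(=O)C(c2ccc(F)cc2)c2ccc(NS(C)(=O)=O)c(F)c2)CC1` gives 3.4 nM in this assay.

On these two numbers compound 2 holds the higher one, separated from compound 1 by a 2.6-fold higher number from compound 1 to compound 2 (0.42 log units; beyond the scatter). Compound 3 `CC1CCN(c2nc(C(F)(F)F)ccc2CNC(=O)C(Cc2ccccc2)c2ccc(NS(C)(=O)=O)c(F)c2)CC1` is the compound still to be measured; it differs from compound 2 by benzyl in place of 4-fluorophenyl on a saturated chain carbon bound to an aromatic carbon and a carbonyl carbon.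

Among the compounds with values here, only one measured step exists, a 2.6-fold higher number from compound 1 to compound 2 (0.42 log units; beyond the scatter), and it concerns a fluoro in place of hydrogen on the aromatic ring, not the replacement of that ring by a benzyl group. Within the data shown here, no measured pair shows the change from compound 2 to compound 3, so neither its direction nor its size can be read from the data, and the expectation carries a wide range. For compound 3 the step from compound 2 is estimated as a 2.4-fold higher number from compound 2 to compound 3 (0.37 log units; beyond the scatter). In this assay compound 3 is expected at about 8 nM, with a range from 2 nM to 40 nM.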

Compound 3, inhibition constant: 65.9 nM
Compound 3: the middle estimate sits 8.2-fold (0.92 log units) below what was measured; measured number outside the range, above it.
By their numbers in this assay, from the lowest: compound 1; then compound 2; then compound 3.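

In this assay, benzyl in place of 4-fluorophenyl on a saturated chain carbon bound to an aromatic carbon and a carbonyl carbon gives a 19-fold higher number from compound 2 to compound 3 (1.29 log units; beyond the scatter) and benzyl in place of phenyl at the same carbon gives a 51-fold higher number from compound 1 to compound 3 (1.70 log units; beyond the scatter), both large where the fluoro change on the ring was modest. Benzyl and 4-fluorophenyl count the same heavy atoms and each carry one six-membered aromatic ring, so these counts do not follow the rise in the number. Nothing given here accounts for that rise.

On these data alone, whether fluoro on the benzyl ring would shift the number as it does on the phenyl ring remains open. So does the result at this carbon for a longer chain such as phenethyl, or for an amine.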